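Chain Terminus Swap: Dioxolanyl to Dimethylamino on the Core

The source may hold more compounds than are shown below. What is called first, only, known or untested is meant among the compounds shown, and "the series" means these compounds.

Measured compounds in an assay on NK92 cells for inhibition of interleukin-15 (Homo sapiens), read by AlphaScreen, with stated times of 30 min and 1 h; a lower number here means a stronger inhibitor, a higher number a weaker inhibitor:
Compound 1 `Cn1nc(Cc2nnc(SCC(=O)Nc3ccc(Cl)cc3Cl)n2CCC=O)c2ccccc2c1=O`: 4200 nM
Compound 2 `Cn1nc(Cc2nnc(SCC(=O)Nc3ccc(Cl)cc3Cl)n2CCCO)c2ccccc2c1=O`: > 30000 nM
Compound 3 `Cn1c(Cc2nn(CCC3OCCO3)c(=O)c3ccccc23)nnc1SCC(=O)Nc1ccc(Cl)cc1Cl`: 30000 nM

Compound 3 stands highest of the two numbers available in this assay, an at least 7.1-fold higher number from compound 1 to compound 2 (0.85 log units; beyond the scatter) -sized gap separating it from nothing directly, but its value sits well above that of compound 1. The value of compound 2 is a limit of this assay, not a number (the limit of > 30000 nM in this assay, at which 1 of the 3 values shown sits).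

Compound 4 `CN(C)CCCn1nc(Cc2nnc(SCC(=O)Nc3ccc(Cl)cc3Cl)n2C)c2ccccc2c1=O` is not yet measured. Relative to compound 3 it carries (dimethylamino)methyl in place of 1,3-dioxolan-2-yl on a saturated chain carbon, two bonds along the chain from an aromatic nitrogen. Among the measured compounds shown here, only one measured step touches the same place: the step of an at least 7.1-fold higher number from compound 1 to compound 2 (0.85 log units; beyond the scatter), where a different swap at the chain terminus moved the number beyond the scatter. That step shows the terminus matters but does not involve either group present here, so no direction can be read from it. The estimate for compound 4 is therefore centred near compound 3, with wide bounds: 20000 nM, from 4000 nM to 60000 nM, a step of a 1.5-fold lower number from compound 3 to compound 4 (0.18 log units; within the scatter) expected to be within the scatter.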

Compound 4, half-maximal inhibitory concentration: > 30000 nM
Compound 4 ended at the assay's limit; the forecaster's own chance of this, stated with the estimate: 40%; middle value at least 1.5-fold (0.17 log units) from the limit.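

Replacing 1,3-dioxolan-2-yl with (dimethylamino)methyl on a saturated chain carbon, two bonds along the chain from an aromatic nitrogen, gives a number no lower from compound 3 to compound 4 (the limit leaves the size open), so the ring-free terminus bearing a nitrogen brings no gain at this place. The earlier compounds had shown only that a change of terminus could raise the number, and this is the first change of the dioxolane terminus itself. Compound 4 is reported only as a limit, and it joins compound 2 there: the limit of > 30000 nM in this assay, at which 2 of the 4 values shown sit.

From the compounds shown here alone, how far compound 4 lies beyond that limit stays open, so the two termini cannot be ranked. Also open, going by these compounds, is whether a carboxylic acid, a primary amine or a longer chain at this place would bring the number down.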